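Sulfoxide series: oxadiazole in place of the acetate ester

The source may hold more compounds than are shown below. What is called first, only, known or untested is meant among the compounds shown, and "the series" means these compounds.

Compound 2 `CC(=O)OCC[S+]([O-])CC1CN(C)CCC1c1ccc(Cl)cc1` is the sulfoxide of the series. In an assay on isolated protein for inhibition of Norepinephrine transporter (Rattus norvegicus), read by radioligand binding (on this read-out higher numbers stand for weaker inhibition and lower numbers for stronger inhibition), compound 2 gives 29 nM, the highest of the three numbers measured. The sulfide compound 1 `CC(=O)OCCSCC1CN(C)CCC1c1ccc(Cl)cc1` gives 3.6 nM, and the benzoate analogue compound 3 `CN1CCC(c2ccc(Cl)cc2)C(CSCCOC(=O)c2ccccc2)C1` gives 4.5 nM; both numbers stand well apart from compound 2, beyond the scatter.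

Compound 4 `Cc1noc(C[S+]([O-])CC2CN(C)CCC2c2ccc(Cl)cc2)n1` is the next compound to be measured. It differs from compound 2 by 3-methyl-1,2,4-oxadiazol-5-yl in place of acetoxymethyl on a saturated chain carbon bound to a sulfur. Among the compounds with values here, the only measured step within the set is a 1.3-fold higher number from compound 1 to compound 3 (0.10 log units; within the scatter), which changes the group at the far end of the chain and stays within the scatter. Within the data shown here, no measured step changes the ester itself on the sulfoxide core. Among the measured compounds shown here, only the step from compound 1 to compound 3 speaks to this end of the molecule, and it was flat. The step from compound 2 to compound 4 is therefore expected to be about a 1.2-fold lower number from compound 2 to compound 4 (0.06 log units; within the scatter), with no change beyond the scatter. For compound 4 a value of 25 nM in this assay is estimated, in a range from 8 nM to 80 nM.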

Compound 4, inhibition constant: 218 nM
The estimate for compound 4 lay 8.7-fold (0.94 log units) below the measured number; the measured number lies above the stated range.
By their numbers in this assay, from the lowest: compounds 1 and 3 (each within the scatter of the next); then compound 2; then compound 4.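

On the sulfoxide core, this assay registers a 7.5-fold higher number from compound 2 to compound 4 (0.88 log units; beyond the scatter), so this end of the molecule is not indifferent to every change on a saturated chain carbon bound to a sulfur. The earlier step, a 1.3-fold higher number from compound 1 to compound 3 (0.10 log units; within the scatter), was made on the sulfide and kept the ester while exchanging only the group on the carbonyl carbon; its flat result does not carry over to replacing acetoxymethyl with 3-methyl-1,2,4-oxadiazol-5-yl. No evidence at hand bears on the reason for this rise.

The compounds shown leave open whether an amide or a carboxylic acid in place of acetoxymethyl would stay close to compound 2, and whether a longer chain carrying the oxadiazole would recover the lost ground. As far as these compounds go, the same replacement on the sulfide core of compound 1 also remains open.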